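Swapping a ring on the core of compound 1

This account rests on a few compounds, and the source may have more. Where it says the series, first, only, none or still open, it means among the compounds named here.

Values in a physicochemical assay for solubility (on this read-out higher numbers stand for higher solubility and lower numbers for lower solubility), so far
Compound 1 (`C[C@@H]1CN(c2cc(C(F)(F)F)nn2-c2ccc(S(C)(=O)=O)cn2)[C@H](C)CO1`) gives 100 ug/mL
Compound 2 (`C[C@@H]1CN(c2c(C#N)c(C(F)(F)F)nn2-c2ccc(S(C)(=O)=O)cn2)[C@H](C)CO1`) gives > 200 ug/mL as a limit of the assay, not a number
Compound 3 (`CS(=O)(=O)c1ccc(-n2nc(C(F)F)c(C#N)c2NC2CCCC2)cc1`) gives 100 ug/mL

Compound 1 stands level with compound 3 at these digits, and both sit under the limit reached by compound 2. Compound 4 (`CS(=O)(=O)c1ccc(-n2nc(C(F)(F)F)cc2OC2CCCC2)nc1`) has not yet been measured. Compared with compound 1, it carries a group of 6 heavy atoms (5 carbon, 1 oxygen; one five-membered non-aromatic ring of carbon only) in place of a group of 8 heavy atoms (6 carbon, 1 nitrogen, 1 oxygen; one six-membered non-aromatic ring with 2 hetero atoms), on an aromatic carbon, with cyclopentyloxy as the entering group.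

Within the data shown here, the only measured step is an at least 2.0-fold higher number from compound 1 to compound 2 (0.30 log units; that floor lies within the scatter). It adds a nitrile and does not touch the place that changes here, so it gives no size for this swap. Compound 3 also holds a five-membered non-aromatic ring of carbon only and gives 100 ug/mL, but it has a nitrile, which compound 4 lacks. A modest fall is therefore expected, though with little support, and the estimated change is a 2.5-fold lower number from compound 1 to compound 4 (0.40 log units; beyond the scatter). For compound 4 the estimate in this assay is 40 ug/mL, with an expected range of 10 ug/mL to 120 ug/mL.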

Compound 4, solubility: 50 ug/mL
Beside the measured number, compound 4's estimate is 1.3-fold (0.10 log units) below it, within the range that was stated.
By their numbers in this assay, from the lowest: compounds 4, 1 and 3 (each within the scatter of the next). At a limit, above all of these: compound 2.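

Replacing the ring of compound 1, with its 2 defined stereocentres, by cyclopentyloxy on an aromatic carbon of the five-membered aromatic ring gives a 2.0-fold lower number from compound 1 to compound 4 (0.30 log units; within the scatter) in this assay. Among these compounds, this is the first reading at this position, as the only earlier step adds a nitrile at another place. At the precision of this read-out, the two groups cannot be told apart here, so this swap shows no real effect on the number. No measurement shown gives a cause for this step.

The swap alters the ring and its link to the core together, so the compounds shown cannot separate the two. Also open, going by these compounds, is how a carboxylic acid, a primary amine or a longer chain such as hexyloxy would read at this position, and whether a nitrile added to compound 4 would act as it did in compound 2.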